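Shortening the chain of compound 1

The compounds below may be only part of what the source reports. "The series", "measured", "known", "first", "only" and "open" are said of these compounds alone.

Values in a functional assay on A549 cells (Homo sapiens) for antiproliferative activity; a lower number here means that less compound is needed, a higher number that more compound is needed for the effect:
compound 1 `CCCCCCCCCCCCO/N=C(\CCCCCC)c1cc(OC)c2c(c1OC)C(=O)C=CC2=O`: > 10 ug/mL, a limit
compound 2 `CCCCCCCO/N=C/c1cc(OC)c2c(c1OC)C(=O)C=CC2=O`: > 10 ug/mL, a limit
compound 3 `CCCCCO/N=C/c1cc(OC)c2c(c1OC)C(=O)C=CC2=O`: > 10 ug/mL, a limit

Compound 1 stands at the limit of > 10 ug/mL in this assay, at which 3 of the 3 values shown sit, so its position is a limit and not a number. Compound 4 `CCCCCCCCCO/N=C(\CCCCCC)c1cc(OC)c2c(c1OC)C(=O)C=CC2=O` differs from compound 1 by hydrogen in place of propyl on a saturated chain carbon, nine bonds along the chain from an oxygen on an unsaturated carbon. The one measured chain shortening is a step that the two limits leave unreadable from compound 2 to compound 3, so it supplies no size or direction to carry over. The expected change is therefore no readable shift, given as a step that the limit leaves unreadable from compound 1 to compound 4. For compound 4 the estimate is 15 ug/mL, with an expected range of 6 ug/mL to 40 ug/mL, and another limit is the likeliest report.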

Compound 4, concentration for half-maximal effect: > 10 ug/mL
Compound 4 gave a limit, no number; the forecaster's own chance of this, stated with the estimate: 75%; the middle value does not contradict the limit.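

Compound 1 and compound 4 both give only a limit in this assay, so no step between them can be read: the limit of > 10 ug/mL in this assay, at which 4 of the 4 values shown sit.

The compounds shown leave open whether any chain length on the shared core gives a measurable value in this assay.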